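Exchanging a Chloroalkyl Amide for a Dichloropyridinyl Amide

The compounds below may be only part of what the source reports. "The series", "measured", "known", "first", "only" and "open" are said of these compounds alone.

Compound 1 `C=CC(=O)Nc1cccc(-c2nc3ccccc3s2)c1`: 797 10^-6 cm/s
Compound 2 `C/C=C/C(=O)Nc1cccc(-c2nc3ccccc3s2)c1`: 1640 10^-6 cm/s
Compound 3 `CC(C)(CCl)C(=O)Nc1cccc(-c2nc3ccccc3s2)c1`: 891 10^-6 cm/s

In an ADME assay for permeability, using PAMPA (a higher number here means that the compound crosses the layer faster, a lower number that the compound crosses the layer more slowly), compound 3 stands second highest of the three numbers, with compound 1 nearest and compound 2 furthest. Compound 4 `O=C(Nc1cccc(-c2nc3ccccc3s2)c1)c1ccc(Cl)nc1Cl` is the next compound, carrying (2,6-dichloropyridin-3-yl in place of 1-(chloromethyl)-1-methylethyl on a carbonyl carbon). Among the compounds with values here, the steps that bear on this change are a 1.1-fold higher number from compound 1 to compound 3 (0.05 log units; within the scatter) and a 1.8-fold lower number from compound 2 to compound 3 (0.26 log units; within the scatter), both within the scatter, while a 2.1-fold higher number from compound 1 to compound 2 (0.31 log units; beyond the scatter) was the only modest change seen among the measured amides. All three acyl groups on the shared core therefore sit close together in this assay, and compound 4 is expected to do the same, with a step of a 1.0-fold higher number from compound 3 to compound 4 (0.00 log units; within the scatter), not beyond the scatter. Compound 4 is estimated at 900 10^-6 cm/s, in a range from 450 10^-6 cm/s to 1800 10^-6 cm/s.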

Compound 4, apparent permeability: 104 10^-6 cm/s
Compound 4: the middle estimate sits 8.7-fold (0.94 log units) above what was measured; measured number below the stated range.
By their numbers in this assay, from the lowest: compound 4; then compounds 1, 3 and 2 (each within the scatter of the next, the first and the last beyond it).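

In this assay the carbonyl carbon proves far less tolerant than the three earlier acyl groups suggested: 2,6-dichloropyridin-3-yl gives an 8.6-fold lower number from compound 3 to compound 4 (0.93 log units; beyond the scatter) and a 7.7-fold lower number from compound 1 to compound 4 (0.88 log units; beyond the scatter) and a 16-fold lower number from compound 2 to compound 4 (1.20 log units; beyond the scatter) in a single exchange. It is the only group shown with an aromatic ring and a hydrogen-bond acceptor, and its ring, nitrogen and chlorines all enter together. Nothing available accounts for the drop.

Which of these features carries the step remains open. Plain phenyl or an unsubstituted pyridine on the carbonyl carbon would separate the ring from its chlorines.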